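The compounds below may be only part of what the source reports. "The series", "measured", "known", "first", "only" and "open" are said of these compounds alone.

Series notes. Compound 1 `O=C1C(Nc2ccccc2F)=CC(=O)c2c1nc1n2[C@H]2OC[C@@H](O)[C@H]2OC1` is the reference point; in a functional assay on HeLa cells (Homo sapiens) for inhibition, read by sulforhodamine B assay (on this read-out higher numbers stand for weaker inhibition and lower numbers for stronger inhibition), compound 1 gives 9820 nM. Of the two numbers shown, compound 1 stands highest; its nearest neighbour is compound 3 `COc1ccccc1NC1=CC(=O)c2nc3n(c2C1=O)[C@H]1OC[C@@H](O)[C@H]1OC3`, which in this assay gives 2950 nM, a gap beyond the scatter. Compound 2 `O=C1C=C(NC2CCCCC2)C(=O)c2c1nc1n2[C@H]2OC[C@@H](O)[C@H]2OC1` gives in this assay only a limit, > 16000 nM (the limit of > 16000 nM in this assay, at which 1 of the 3 values shown sits). Within the data shown here, the single measured step, an at least 5.4-fold lower number from compound 2 to compound 3 (0.73 log units; beyond the scatter), shows a six-membered aromatic ring of carbon only on the amine nitrogen giving a lower number than cyclohexyl.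

Compound 4 `COc1cccc(NC2=CC(=O)c3c(nc4n3[C@H]3OC[C@@H](O)[C@H]3OC4)C2=O)c1` is not yet measured. It differs from compound 1 by 3-methoxyphenyl in place of 2-fluorophenyl on an amine nitrogen. Among the measured compounds shown here, no measured step covers this exact change; the nearest comparison is compound 1 with 2-fluorophenyl against compound 3 with 2-methoxyphenyl, the latter lower. A six-membered aromatic ring of carbon only is kept, so nothing of the size of an at least 5.4-fold lower number from compound 2 to compound 3 (0.73 log units; beyond the scatter) is expected, rather a modest lowering toward compound 3, with wide uncertainty. For compound 4 the expected step is a 1.8-fold lower number from compound 1 to compound 4 (0.25 log units; within the scatter). Compound 4 is estimated at 5500 nM, with a range from 2000 nM to 15000 nM.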

Compound 4, half-maximal inhibitory concentration: > 8000 nM
Compound 4: no number, only a limit; the forecaster's own chance of this, stated with the estimate: 10%; middle value at least 1.4-fold (0.16 log units) from the limit.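

In this assay compound 4 gives only a limit, > 8000 nM. The step between compound 1 and compound 4 therefore cannot be read. The compounds shown leave open whether (3-methoxyphenyl)amino gives a higher or lower number than (2-fluorophenyl)amino on the shared core.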